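A few compounds are considered here, and "the series" means these few. Any claim that something is new, unique, unknown or untested is made for them only; others in the source may bear on it.

Within the data shown here, compound 2 `COc1ccc(-c2cc(NNC(=O)Nc3cc(Cl)nc(Cl)c3)nc3c2c(C)nn3C)cc1` gives 82300 nM in a functional assay on HCT-116 cells (Homo sapiens) for cytotoxicity, read by MTT assay, with a stated time of 48 h, in the presence of a further agent that is not named here (a lower number here means that less compound is needed, a higher number that more compound is needed for the effect), the higher of the two numbers so far. Compound 1 `Cc1nn(C)c2nc(NNC(=O)Nc3cc(Cl)nc(Cl)c3)cc(-c3ccc(F)cc3)c12` gives 25200 nM in this assay, and the step of a 3.3-fold higher number from compound 1 to compound 2 (0.51 log units; beyond the scatter) concerns methoxy in place of fluoro on an aromatic carbon. Compound 3 `Cc1cc(NNC(=O)Nc2cc(Cl)nc(Cl)c2)nc2c1c(C)nn2C` differs from compound 2 by methyl in place of 4-methoxyphenyl on an aromatic carbon. Among the measured compounds shown here, no measured step removes the 4-methoxyphenyl itself, so the one step known only indicates that changes at this end of the molecule register in this assay, and no direction beyond the scatter is expected. Compound 3 is estimated at 60000 nM, with a range of 15000 nM to 250000 nM. The expected step is a 1.4-fold lower number from compound 2 to compound 3 (0.14 log units; within the scatter).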

Compound 3, half-maximal effective concentration: > 100000 nM
Compound 3 gave a limit, no number; the forecaster's own chance of this, stated with the estimate: 25%; at least 1.6-fold (0.22 log units) between middle value and limit.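

In this assay compound 3 gives a limit and not a number: the limit of > 100000 nM in this assay, at which 1 of the 3 values shown sits. Methyl in place of 4-fluorophenyl gives an at least 3.9-fold higher number from compound 1 to compound 3 (0.59 log units; beyond the scatter), the first sign that replacing the whole aryl group at this position, not just its substituent, can raise the number beyond the scatter. Methyl in place of 4-methoxyphenyl gives an at least 1.2-fold higher number from compound 2 to compound 3 (0.08 log units; that floor lies within the scatter), a floor too small to establish a change.

On these data alone, the true distance of compound 3 past its limit remains unknown. As far as these compounds go, whether an amine or a longer alkyl chain at this position would behave like methyl or like the aryl groups also remains open.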